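Chain length to benzyl on the shared core

The source may report more compounds than this note shows. Statements on the series, on what has been measured and on what is new or still open speak of the compounds shown alone.

Measured in a functional assay on T47D cells (Homo sapiens) for antiproliferative activity, read by MTT assay, with a stated time of 72 h; on this read-out higher numbers stand for weaker inhibition and lower numbers for stronger inhibition:
- Compound 1 `COc1cc(-c2nccn2C)cc(OC)c1OC`: > 100000 nM, a limit
- Compound 2 `CCn1ccnc1-c1cc(OC)c(OC)c(OC)c1`: > 100000 nM, a limit
- Compound 3 `CCCCCn1ccnc1-c1cc(OC)c(OC)c(OC)c1`: 64400 nM

Within the data shown here, compound 3 holds the only actual number, at 64400 nM. The other compounds stop at the limit of > 100000 nM in this assay, at which 2 of the 3 values shown sit.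

The next compound, compound 4 `COc1cc(-c2nccn2Cc2ccccc2)cc(OC)c1OC`, departs from compound 3 by one change: phenyl in place of butyl on a saturated chain carbon bound to an aromatic nitrogen. In words, this is phenyl in place of butyl on a saturated chain carbon bound to an aromatic nitrogen. Cut one bond further out, the same difference reads pentyl to benzyl.

Among the measured compounds shown here, the steps that bear on this change are those at the same place on the chain. They are a step that the two limits leave unreadable from compound 1 to compound 2, an at least 1.5-fold lower number from compound 1 to compound 3 (0.19 log units; that floor lies within the scatter) and an at least 1.5-fold lower number from compound 2 to compound 3 (0.19 log units; that floor lies within the scatter). None of them puts a ring at this place, so they give only a loose guide.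

With compound 3 at 64400 nM as the sole anchor, and with the two readable steps having floors within the scatter, no clear shift is expected in this assay. The expected outcome is a 1.1-fold higher number from compound 3 to compound 4 (0.04 log units; within the scatter), which is no step beyond the scatter. For compound 4 the estimated value is 70000 nM, with an expected range from 30000 nM to 150000 nM.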

Compound 4, half-maximal inhibitory concentration: > 100000 nM
Compound 4: only a limit was reported; the forecaster's own chance of this, stated with the estimate: 45%; middle value at least 1.4-fold (0.15 log units) away from the limit.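

In this assay, putting a ring on this chain carbon brings no readable gain over the butyl it replaces, the change giving an at least 1.5-fold higher number from compound 3 to compound 4 (0.19 log units; that floor lies within the scatter). Benzyl, the first ring at this place, thus falls with compound 1 and compound 2 at the assay limit rather than with the pentyl of compound 3, and the steps from compound 1 and compound 2 to compound 4 cannot be read. Compound 3 therefore stays the only compound with an actual number, and the series now rests mostly on one limit: the limit of > 100000 nM in this assay, at which 3 of the 4 values shown sit.

On these data alone, how far past that limit compound 4 lies remains open, and with it whether pentyl and benzyl truly differ by more than the scatter. Also open, as far as these compounds go, is whether a longer chain such as hexyl, or a benzyl ring carrying an amine or a carboxylic acid, would give a second actual number at this place on the shared core.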